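Rhodanine-oxindole series: replacing the anilide arm with a benzyl group

The source may report more compounds than this note shows. Statements on the series, on what has been measured and on what is new or still open speak of the compounds shown alone.

Measured so far:
compound 1, `Cc1cccc(NC(=O)CN2C(=O)/C(=C3\SC(=S)N(CCS(=O)(=O)O)C3=O)c3ccccc32)c1`, 6%
compound 2, `O=C(O)CCCCCN1C(=O)/C(=C2/C(=O)N(Cc3ccccc3)c3ccccc32)SC1=S`, 13%

Both measured compounds were run in an assay for inhibition of histone acetyltransferase KAT2B (Homo sapiens), read by TR-FRET, with a stated time of 10 min, tested at 50 uM; on this read-out lower numbers stand for less inhibition and higher numbers for more inhibition at the one concentration tested (going by the name of the read-out). Compound 1 gives 6% and compound 2 gives 13%; the gap between them lies within the scatter, so compound 1 cannot be placed apart from compound 2, and the two only show that this core has given weak inhibition at the single concentration so far.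

Compound 3, `Cc1ccc(CN2C(=O)/C(=C3\SC(=S)N(CCS(=O)(=O)O)C3=O)c3ccccc32)cc1`, has not been measured. Its structure differs from compound 1 in one place: 4-methylphenyl in place of (3-methylphenyl)carbamoyl on a saturated chain carbon bound to an amide-type nitrogen in a ring. The change removes the hydrogen-bond donor and acceptor counted for the leaving group and brings in a smaller group of carbon atoms only. Within the data shown here, no step between measured compounds is available to weigh this change, and compound 2, which also carries a benzyl-type group on the core nitrogen, sits within the scatter of compound 1.

With nothing in the data pointing either way, the step of a number 2 percentage points higher from compound 1 to compound 3 (within the scatter) is expected to stay within the scatter. Compound 3 is therefore estimated at 8%, within the range -6% to 22%.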

Compound 3, a percentage reported as inhibition, at one concentration (the size of the read-out at that concentration, not a potency): < 5%
Compound 3: only a limit was reported; the forecaster's own chance of this, stated with the estimate: 5%; at least 3 percentage points between middle value and limit.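

In this assay compound 3 gives < 5%, which is a limit of the assay and not a number. Among these compounds, this is the first one-place reading at the saturated chain carbon bound to an amide-type nitrogen in a ring: with 4-methylphenyl in place of (3-methylphenyl)carbamoyl, the series shows a number at least 1 percentage points lower from compound 1 to compound 3 (that floor lies within the scatter), so the loss of the hydrogen-bond donor and acceptor counted for the leaving group brings no rise in inhibition at the one concentration tested. The step is a floor only, so its true size cannot be read and the change cannot be placed beyond the scatter: the limit of < 5% in this assay, at which 1 of the 3 values shown sits.

Both compounds of this pair sit at weak inhibition, so the pair does not say whether any group at this place can lift the read-out clear of the scatter. An arm ending in a carboxylic acid or an amine at this place, or a longer chain between the ring nitrogen and the aromatic ring, lies outside the compounds shown, and what such groups would do remains open.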